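From ethynyl to 2-phenylethynyl: compound 3 to compound 4

This account rests on a few compounds, and the source may have more. Where it says the series, first, only, none or still open, it means among the compounds named here.

Measured in a functional assay on L1210 cells (Mus musculus) for inhibition; on this read-out higher numbers stand for weaker inhibition and lower numbers for stronger inhibition:
- compound 1 `NC(=O)c1ncn(C2O[C@H](CO)[C@@H](O)[C@H]2O)c1C#CCO` gives 0.7 ug/mL
- compound 2 `NC(=O)c1ncn(C2O[C@H](CO)[C@@H](O)[C@H]2O)c1C#CCCO` gives 1.28 ug/mL
- compound 3 `C#Cc1c(C#N)ncn1C1O[C@H](CO)[C@@H](O)[C@H]1O` gives 1.9 ug/mL

Compound 3, at 1.9 ug/mL, cannot be told apart from compound 2, at 1.28 ug/mL. Its number does lie above that of compound 1, at 0.7 ug/mL, by more than the usual scatter, which means weaker inhibition.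

The next compound to be tested is compound 4 `N#Cc1ncn(C2O[C@H](CO)[C@@H](O)[C@H]2O)c1C#Cc1ccccc1`. It differs from compound 3 by phenyl in place of hydrogen on a triple-bonded carbon, so ethynyl becomes 2-phenylethynyl.

For the measured compounds named here, only one measured step offers any guidance. In a 1.8-fold higher number from compound 1 to compound 2 (0.26 log units; within the scatter), hydroxymethyl replaces hydroxy on a saturated chain carbon bound to a triple-bonded carbon, and that step stayed within the scatter. Going by the values given here, it is a different and smaller change than adding a whole ring, and no measured compound carries a phenyl, so it bears on this question only weakly. A move towards weaker inhibition, somewhat beyond the scatter, is therefore a cautious expectation rather than a firm one. In this assay the expected step is a 3.2-fold higher number from compound 3 to compound 4 (0.50 log units; beyond the scatter). The estimate for compound 4 is 6 ug/mL, with an expected range of 1.5 ug/mL to 30 ug/mL.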

Compound 4, half-maximal inhibitory concentration: 80.3 ug/mL
Compound 4: the middle estimate sits 13-fold (1.13 log units) below what was measured; the whole stated range lies below it.
By their numbers in this assay, from the lowest: compounds 1, 2 and 3 (each within the scatter of the next, the first and the last beyond it); then compound 4.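

In this assay, the triple-bonded carbon proves to be a sensitive place: phenyl in place of hydrogen there gives a 42-fold higher number from compound 3 to compound 4 (1.63 log units; beyond the scatter), a large move towards weaker inhibition. The earlier change at the far end of the triple bond, a 1.8-fold higher number from compound 1 to compound 2 (0.26 log units; within the scatter), stayed within the scatter and gave no sign that a change in this region could cost so much, although that pair carries a different group elsewhere on the shared core. The compounds shown include no measurement that speaks to the reason for the large step.

Going by these compounds, it remains open whether any carbon group on this triple-bonded carbon brings a similar loss, or whether the loss belongs to the aromatic ring of phenyl, and a small methyl or a longer saturated alkyl chain in the same place would help to separate the two. Also open, on these data alone, is whether a chain ending in an amine or a carboxylic acid would keep inhibition close to that of compound 3, at 1.9 ug/mL, or lose it as compound 4 does.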